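Removing the Nitro Group from Compound 2

This account rests on a few compounds, and the source may have more. Where it says the series, first, only, none or still open, it means among the compounds named here.

Compound 1 (`CC(=NNC(=S)Nc1cccc([N+](=O)[O-])c1)c1ccccn1`): 38 nM
Compound 2 (`CC(=NNC(=S)Nc1ccccc1[N+](=O)[O-])c1ccccn1`): 5.7 nM

In a functional assay on MCF7 cells (Homo sapiens) for cytotoxicity, read by MTT assay, with a stated time of 48 h (a higher number here means a weaker inhibitor, a lower number a stronger inhibitor), compound 2 stands lowest of the two at 5.7 nM and lies beyond the scatter from compound 1. Compound 3 (`CC(=NNC(=S)Nc1ccccc1)c1ccccn1`) has hydrogen in place of nitro on an aromatic carbon. For the measured compounds named here, no measured pair shows this change on its own, so the size of the step is uncertain. Going by the values given here, the only other value, compound 1 at 38 nM with its nitro retained, is a rough guide. The expected change is a 7.0-fold higher number from compound 2 to compound 3 (0.85 log units; beyond the scatter) (upward, towards a weaker inhibitor, beyond the scatter). Compound 3 is estimated at 40 nM (expected range 8 nM to 200 nM).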

Compound 3, half-maximal inhibitory concentration: 0.18 nM
For compound 3 the middle estimate is 220-fold (2.35 log units) above the measured one, and the stated range ends above it.
By their numbers in this assay, from the lowest: compound 3; then compound 2; then compound 1.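

In this assay, the nitro group is not needed for a low number: replacing it with hydrogen gives a 32-fold lower number from compound 2 to compound 3 (1.50 log units; beyond the scatter) and also a 210-fold lower number from compound 1 to compound 3 (2.32 log units; beyond the scatter) across these compounds. Both earlier compounds carried a nitro group, so only compound 3 reveals that the bare aromatic carbon gives the lowest number of the three. Nothing available explains this gain. From the compounds shown here alone, whether an amine or a methoxy group on this aromatic carbon would match hydrogen remains open, and so does whether any substituent here can give a lower number than compound 3.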